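A few compounds are considered here, and "the series" means these few. Any claim that something is new, unique, unknown or untested is made for them only; others in the source may bear on it.

Measured compounds:
- compound 1 `CC(C)(C)CC(=O)N(CCCCCCN1C[C@H](O)[C@@H](O)[C@H](O)[C@H]1CO)C1CCCCC1` — > 500000 nM
- compound 2 `CC(C)(C)C(=O)N(CCCCCCN1C[C@H](O)[C@@H](O)[C@H](O)[C@H]1CO)c1ccc(F)cc1F` — > 500000 nM
- compound 3 `CC(C)(C)C(=O)N(CCCCCCN1C[C@H](O)[C@@H](O)[C@H](O)[C@H]1CO)C1CCCC1` — > 500000 nM

In an ADME assay on Huh-7 cells (Homo sapiens) for cytotoxicity, read by MTT assay (a lower number here means that less compound is tolerated, a higher number that more compound is tolerated), compound 1 reaches only a limit, > 500000 nM. Compound 2 likewise shows only a limit in this assay, > 500000 nM. Compound 3 also sits at a limit in this assay, > 500000 nM. Going by the values given here, compound 2 thus stands at the same limit as the other two values shown; all three sit at the limit of > 500000 nM in this assay, at which 3 of the 3 values shown sit, so no compound separates from another.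

The change from compound 2 to compound 4 `CC(C)(C)C(=O)N(CCCCCCN1C[C@H](O)[C@@H](O)[C@H](O)[C@H]1CO)C1CCCCCC1` is cycloheptyl in place of 2,4-difluorophenyl on an amide-type nitrogen. Among the compounds with values here, the nearest measured step is the one from compound 2 to compound 3, a step that the two limits leave unreadable from compound 2 to compound 3, where the two limits leave its size unreadable. Nothing measured here therefore points to a readable step in this assay in either direction, and the step from compound 2 to compound 4 is expected to be a number no higher from compound 2 to compound 4 (the limit leaves the size open), most likely again ending at the limit. For compound 4 the estimate in this assay is 500000 nM, with a range of 200000 nM to 1000000 nM.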

Compound 4, half-maximal cytotoxic concentration: > 500000 nM
Compound 4 ended at the assay's limit; the forecaster's own chance of this, stated with the estimate: 85%; the middle value sits exactly at the limit.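

In this assay compound 4 gives > 500000 nM, a limit and not a number. The steps from compound 2 and from compound 3 to compound 4 therefore cannot be read. The compounds shown leave open at what concentration any of them becomes cytotoxic, and whether the group on the amide-type nitrogen alters that concentration.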